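Adding an Amide Arm to a Weak Cell-Growth Inhibitor

A few compounds are considered here, and "the series" means these few. Any claim that something is new, unique, unknown or untested is made for them only; others in the source may bear on it.

Three close relatives share one core and differ only in what hangs on a saturated chain carbon bound to a sulfur. In a functional assay on HepG2 cells (Homo sapiens) for inhibition, read by MTT assay, with a stated time of 48 h (a lower number here means a stronger inhibitor, a higher number a weaker inhibitor), compound 1 `COc1ccc(-n2c(SC)nnc2-c2cc(OC)c(OC)c(OC)c2)cc1` reaches only the limit of the assay, > 60000 nM, so its potency is known only as a bound. Compound 2 `COc1ccc(-n2c(SCc3ccc(F)cc3)nnc2-c2cc(OC)c(OC)c(OC)c2)cc1`, which carries 4-fluorophenyl at that place, gives 35000 nM in this assay. Compound 3 `CCOC(=O)CSc1nnc(-c2cc(OC)c(OC)c(OC)c2)n1-c1ccc(OC)cc1`, with ethoxycarbonyl at the same place, again returns only the limit, > 60000 nM. The step of an at least 1.7-fold lower number from compound 1 to compound 2 (0.23 log units; that floor lies within the scatter) and the step of an at least 1.7-fold higher number from compound 2 to compound 3 (0.23 log units; that floor lies within the scatter) are both floors that lie within the usual scatter, and the step that the two limits leave unreadable from compound 1 to compound 3 cannot be read because of the limit of > 60000 nM in this assay, at which 2 of the 3 values shown sit.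

Compound 4 `COc1ccc(NC(=O)CSc2nnc(-c3cc(OC)c(OC)c(OC)c3)n2-c2ccc(OC)cc2)cc1` has not yet been measured. It differs from compound 1 by (4-methoxyphenyl)carbamoyl in place of hydrogen on a saturated chain carbon bound to a sulfur. Among the measured steps, the ethoxycarbonyl of compound 3 is the nearest precedent and the aromatic ring of compound 2 the other; neither moved the number beyond the scatter, and one of them stayed at the limit. The expectation for compound 4 is therefore a step of an at least 1.3-fold lower number from compound 1 to compound 4 (0.12 log units; that floor lies within the scatter), leaving it weak. Compound 4 is expected to give 45000 nM in this assay, within a range from 15000 nM to 150000 nM.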

Compound 4, half-maximal inhibitory concentration: > 60000 nM
Compound 4: only a limit was reported (the forecaster's own chance of this, stated with the estimate: 55%); middle value at least 1.3-fold (0.12 log units) from the limit.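

Compound 4 adds a new kind of group at this position: (4-methoxyphenyl)carbamoyl brings an aromatic ring together with an amide hydrogen, yet in this assay compound 4 gives > 60000 nM, which is a limit of the assay and not a number. Against the 4-fluorophenyl group of the one compound with a measured number, the change gives an at least 1.7-fold higher number from compound 2 to compound 4 (0.23 log units; that floor lies within the scatter), so even this comparison does not separate the two groups clearly. The steps that link compound 4 to compound 1 and compound 3 cannot be read, because each joins one limit to another: the limit of > 60000 nM in this assay, at which 3 of the 4 values shown sit.

The compounds shown leave open whether any group on this saturated chain carbon bound to a sulfur, such as a carboxylic acid, an amine or a longer alkyl chain, would give a number clearly stronger than that of compound 2. They also leave open how far compound 1, compound 3 and compound 4 differ from one another, as their true values lie beyond what this assay reports.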